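The compounds below may be only part of what the source reports. "The series", "measured", "known", "first", "only" and "open" are said of these compounds alone.

Working notes on the series. The three measured compounds share one core and differ only in the aryl group on it: compound 1 `COc1cc(-n2cnc3ccc(-c4cccc(F)c4)cc32)cc(OC)c1OC`, compound 2 `COc1cc(-n2cnc3ccc(-c4ccc(Cl)cc4)cc32)cc(OC)c1OC` and compound 3 `COc1ccc(-c2ccc3ncn(-c4cc(OC)c(OC)c(OC)c4)c3c2)cc1`. In a functional assay on SGC-7901 cells (Homo sapiens) for antiproliferative activity, read by MTT assay, with a stated time of 72 h (a lower number here means a stronger inhibitor, a higher number a weaker inhibitor), compound 1 gives 2490 nM, compound 2 gives 1270 nM and compound 3 gives 82 nM. Compound 3 stands lowest of the three: the nearest is a 15-fold lower number from compound 2 to compound 3 (1.19 log units; beyond the scatter), the furthest is a 30-fold lower number from compound 1 to compound 3 (1.48 log units; beyond the scatter), while a 2.0-fold lower number from compound 1 to compound 2 (0.29 log units; within the scatter).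

Compound 4 `COc1cc(-n2cnc3ccc(-c4ccccc4Cl)cc32)cc(OC)c1OC` is not yet measured. Its change from compound 3 is 2-chlorophenyl in place of 4-methoxyphenyl on an aromatic carbon. Among the compounds with values here, the steps that bear on it are a 15-fold lower number from compound 2 to compound 3 (1.19 log units; beyond the scatter) and a 30-fold lower number from compound 1 to compound 3 (1.48 log units; beyond the scatter), both large, both showing that the halogenated aryl groups measured so far sit well above the methoxy one. Within the data shown here, no measured step places a chloro at this position of the aryl ring, so the size is uncertain, but a large step upward in this assay is expected. Compound 4 is therefore estimated at 2000 nM, range 600 nM to 7000 nM, meaning an expected step of a 24-fold higher number from compound 3 to compound 4 (1.39 log units; beyond the scatter).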

Compound 4, half-maximal inhibitory concentration: > 10000 nM
Compound 4 gave a limit, no number (the forecaster's own chance of this, stated with the estimate: 5%); middle value at least 5.0-fold (0.69 log units) away from the limit.
By their numbers in this assay, from the lowest: compound 3; then compounds 2 and 1 (each within the scatter of the next). At a limit, above all of these: compound 4.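

Compound 4 gives a limit, not a number: the limit of > 10000 nM in this assay, at which 1 of the 4 values shown sits. Within the data shown here, with chlorine kept on the aryl ring, 2-chlorophenyl in place of 4-chlorophenyl gives an at least 7.8-fold higher number from compound 2 to compound 4 (0.89 log units; beyond the scatter), so in this assay the place of the chloro on this ring matters, a point the earlier compounds, which never moved one substituent around the ring, could not show. Against the other two aryl groups the change gives an at least 120-fold higher number from compound 3 to compound 4 (2.08 log units; beyond the scatter) and an at least 4.0-fold higher number from compound 1 to compound 4 (0.60 log units; beyond the scatter), which puts 2-chlorophenyl above all three measured groups and widens the range tolerated at this aromatic carbon.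

The compounds shown leave open whether a methoxy placed elsewhere on the aryl ring keeps the low number of compound 3. They also leave open whether an ethoxy or an amine on that ring does the same.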